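The source may report more compounds than this note shows. Statements on the series, on what has been measured and on what is new or still open speak of the compounds shown alone.

Measured in a functional assay on CUTLL1 cells (Homo sapiens) for inhibition, read by resazurin assay, with a stated time of 48 h, in the presence of a further agent that is not named here; a lower number here means that less compound is needed, a higher number that more compound is needed for the effect:

- compound 1 `Nc1ncc(-c2ccnc3ccccc23)c(C2CC2)n1`: > 100000 nM
- compound 2 `Nc1ncc(-c2ccncc2-c2ccccc2)c(C2CC2)n1`: > 100000 nM
- compound 3 `CC(C)c1nc(N)ncc1-c1ccncc1`: > 100000 nM

Among the compounds with values here, the series so far sits at a single ceiling, (the limit of > 100000 nM in this assay, at which 3 of the 3 values shown sit). Each of these entries is a limit and not a number, so the three compounds cannot be ranked against one another.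

Compound 3 gives > 100000 nM, which is a limit. It is the reference for the next change, but it offers no numerical starting point.

Compound 4 `Nc1ncc(-c2ccncc2)c(-c2ccoc2)n1` carries furan-3-yl in place of isopropyl on an aromatic carbon, next to the ring nitrogen and ortho to a group of 6 heavy atoms (furan-3-yl in place of isopropyl on an aromatic carbon). The rest of the structure is unchanged.

Within the data shown here, no measured step gives a size for a change of this kind. The expectation in this assay rests on compound 3 at > 100000 nM alone. The most likely outcome is that compound 4 also stays at the limit, with a modest shift towards less compound needed as the alternative. The expected change, an at least 1.6-fold lower number from compound 3 to compound 4 (0.22 log units; that floor lies within the scatter), is small and points in that direction. For compound 4 the estimated value is 60000 nM, with an expected range of 10000 nM to 100000 nM.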

Compound 4, half-maximal effective concentration: > 100000 nM
Compound 4: no number, only a limit; the forecaster's own chance of this, stated with the estimate: 65%; middle value at least 1.6-fold (0.22 log units) away from the limit.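

Compound 4 gives > 100000 nM, which is a limit, so the change from compound 3 to compound 4 cannot be read as a step in this assay. All compounds shown share one ceiling: the limit of > 100000 nM in this assay, at which 4 of the 4 values shown sit.

The compounds shown leave open whether any change to the shared core gives a readable value in this assay.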